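Propyl to allyl: an expected step in the series

This account rests on a few compounds, and the source may have more. Where it says the series, first, only, none or still open, it means among the compounds named here.

Measured in a functional assay on MDA-MB-231 cells (Homo sapiens), read by microscopy and transwell migration, with a stated time of 24 h; on this read-out higher numbers stand for weaker inhibition and lower numbers for stronger inhibition:
compound 1 `C=CCn1c(-c2ccc(C)cc2C)cs/c1=N\C(=O)c1ccccc1`: 456 nM
compound 2 `CCn1c(-c2ccccc2)cs/c1=N\C(=O)c1ccccc1`: 51.5 nM
compound 3 `CCCn1c(-c2ccccc2)cs/c1=N\C(=O)c1ccccc1`: 657 nM

Compound 3, at 657 nM, stands level with compound 1 at 456 nM, the two lying within the scatter of each other. Compound 2, at 51.5 nM, has a clearly lower number than either.

The next compound is compound 4 `C=CCn1c(-c2ccccc2)cs/c1=N\C(=O)c1ccccc1`, and the change from compound 3 is vinyl in place of ethyl on a saturated chain carbon bound to an aromatic nitrogen. The same difference reads propyl to allyl, on a saturated chain carbon bound to an aromatic nitrogen.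

Going by the values given here, only one measured step differs in a single place: a 13-fold higher number from compound 2 to compound 3 (1.11 log units; beyond the scatter). It shows that this chain can matter a great deal, but it extends the chain, whereas the present change leaves the heavy-atom count unaltered. Among the compounds with values here, no measured step replaces a saturated chain with an unsaturated one. Compound 1 carries allyl and gives 456 nM, although it also differs from compound 4 elsewhere, so it offers only indirect support.

A value close to that of compound 3 is therefore expected in this assay. The expected step is a 1.5-fold lower number from compound 3 to compound 4 (0.16 log units; within the scatter), which is no change beyond the scatter. For compound 4 the estimated value is 450 nM, with an expected range of 150 nM to 1100 nM.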

Compound 4, half-maximal inhibitory concentration: 1200 nM
For compound 4 the middle estimate is 2.7-fold (0.43 log units) below the measured one; the measured number lies above the stated range.
By their numbers in this assay, from the lowest: compound 2; then compounds 1, 3 and 4 (each within the scatter of the next, the first and the last beyond it).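

In this assay, going by these compounds alone, the first direct exchange of a saturated chain for an unsaturated one at this position gives a 1.8-fold higher number from compound 3 to compound 4 (0.26 log units; within the scatter), so the propyl and allyl compounds stand level and the double bond outside aromatic rings makes no change beyond the scatter here. Among the compounds with a plain phenyl group, the allyl chain lies with propyl, well apart from ethyl, with a 23-fold higher number from compound 2 to compound 4 (1.37 log units; beyond the scatter), so the low number in this small set belongs to the ethyl chain alone. With allyl held constant, the aryl group also shows its first single-place step, a 2.6-fold higher number from compound 1 to compound 4 (0.42 log units; beyond the scatter), a modest difference beyond the scatter that makes compound 1 an imperfect stand-in for compound 4 at the chain position.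

Nothing available accounts for why the ethyl chain stands apart from propyl and allyl. Still open, from the compounds shown here alone, are how a methyl, a butyl or a propargyl chain at this nitrogen would compare, and whether pairing ethyl with 2,4-dimethylphenyl would keep the low number of compound 2 or shift it as that group does in the allyl pair.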